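Direct aryl in place of the alkyne on the nucleoside core

This account rests on a few compounds, and the source may have more. Where it says the series, first, only, none or still open, it means among the compounds named here.

Compound 1 `CCCCC#Cc1cc([C@@H]2O[C@H](CO)[C@@H](O)[C@H]2O)n2ncnc(N)c12` carries a hex-1-yn-1-yl group on the shared core, and in a functional assay on K562 cells (Homo sapiens) for antiproliferative activity, with a stated time of 72 h (a higher number here means a weaker inhibitor, a lower number a stronger inhibitor), compound 1 gives 2400 nM, the lowest of the two numbers available. Compound 3 `Nc1ncnn2c([C@@H]3O[C@H](CO)[C@@H](O)[C@H]3O)cc(-c3ccc(Cl)cc3)c12` bears a 4-chlorophenyl group at the same position, and in this assay compound 3 gives 47800 nM. Compound 2 `Nc1ncnn2c([C@@H]3O[C@H](CO)[C@@H](O)[C@H]3O)cc(C#Cc3ccc(F)cc3)c12` has a 4-fluorophenyl on the triple-bonded carbon; in this assay compound 2 returns only a limit, > 100000 nM. That limit is the limit of > 100000 nM in this assay, at which 1 of the 3 values shown sits, and belongs to compound 2 alone. The step of a 20-fold higher number from compound 1 to compound 3 (1.30 log units; beyond the scatter) shows that exchanging the alkyne for a directly attached aryl ring is costly; the step of an at least 41-fold higher number from compound 1 to compound 2 (1.61 log units; beyond the scatter) shows that extending the alkyne with an aryl is costlier still; the step of an at least 2.0-fold lower number from compound 2 to compound 3 (0.32 log units; beyond the scatter) sets the two aryl variants apart.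

Compound 4 `Nc1ncnn2c([C@@H]3O[C@H](CO)[C@@H](O)[C@H]3O)cc(-c3ccccc3F)c12` differs from compound 1 by 2-fluorophenyl in place of hex-1-yn-1-yl on an aromatic carbon. Among the compounds with values here, the measured step most like this change is a 20-fold higher number from compound 1 to compound 3 (1.30 log units; beyond the scatter), where an aryl ring likewise replaces the alkyne directly on the core; the fluorine position differs, but no measured pair isolates that. A large upward step in this assay is therefore expected. Compound 4 is estimated at 40000 nM, with a range from 10000 nM to 150000 nM. This corresponds to an expected 17-fold higher number from compound 1 to compound 4 (1.22 log units; beyond the scatter).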

Compound 4, half-maximal inhibitory concentration: > 100000 nM
Compound 4: only a limit was reported; the forecaster's own chance of this, stated with the estimate: 25%; middle value at least 2.5-fold (0.39 log units) away from the limit.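

In this assay the value of compound 4 is a limit, the second in the series to stand there: the limit of > 100000 nM in this assay, at which 2 of the 4 values shown sit. The step of an at least 41-fold higher number from compound 1 to compound 4 (1.61 log units; beyond the scatter) shows that the cost of replacing hex-1-yn-1-yl with a directly attached aryl ring is not fixed at the size seen with compound 3, and can be larger at this position on the shared core. Within the data shown here, the step of an at least 2.0-fold higher number from compound 3 to compound 4 (0.32 log units; beyond the scatter) adds what the earlier compounds could not show: directly attached aryl rings are not interchangeable here, since 2-fluorophenyl and 4-chlorophenyl give readably different results, although the halogen and its place on the ring change together, so neither can be credited alone.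

From the compounds shown here alone, compound 2 and compound 4 both carry limits, so the step between them cannot be read and their order remains unknown. Also open, going by these compounds, is whether an unsubstituted phenyl would separate the effect of the halogen from that of the ring itself, and whether an alkyne bearing a longer chain or a terminal amine would keep or improve on the result of compound 1, which gives 2400 nM.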